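Sulfonamide nitrogen substituent: from compound 2 to compound 3

This account rests on a few compounds, and the source may have more. Where it says the series, first, only, none or still open, it means among the compounds named here.

Within the data shown here, in a functional assay on MCF7 cells (Homo sapiens) for antiproliferative activity, read by sulforhodamine B assay, with a stated time of 48 h (a lower number here means a stronger inhibitor, a higher number a weaker inhibitor), compound 2 `Cc1ccc(C)c(NS(=O)(=O)c2ccc(N3CCNC3=O)cc2)c1` gives 48 nM, the lower of the two numbers so far, while compound 1 `O=C1NCCN1c1ccc(S(=O)(=O)Nc2ccccc2)cc1` gives 470 nM. Compound 3 `COc1cccc(NS(=O)(=O)c2ccc(N3CCNC3=O)cc2)c1` has 3-methoxyphenyl in place of 2,5-dimethylphenyl on a sulfonamide nitrogen. Among the measured compounds shown here, the only measured step that bears on this change is a 9.8-fold lower number from compound 1 to compound 2 (0.99 log units; beyond the scatter), made at the same nitrogen. Compound 3 gives up the 2,5-dimethylphenyl that came with that step, so part of the step is expected to be lost in this assay. The expected step is a 4.0-fold higher number from compound 2 to compound 3 (0.60 log units; beyond the scatter), towards a higher number. For compound 3 the estimate is 190 nM, with a range of 60 nM to 600 nM.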

Compound 3, half-maximal inhibitory concentration: 120 nM
Beside the measured number, compound 3's estimate is 1.6-fold (0.20 log units) above it, within the range that was stated.
By their numbers in this assay, from the lowest: compound 2; then compound 3; then compound 1.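

In this assay, a single methoxy on the phenyl ring already lowers the number (a 3.9-fold lower number from compound 1 to compound 3 (0.59 log units; beyond the scatter)), so the gain at the sulfonamide nitrogen does not depend on 2,5-dimethylphenyl alone. Still, 3-methoxyphenyl does not match 2,5-dimethylphenyl (a 2.5-fold higher number from compound 2 to compound 3 (0.40 log units; beyond the scatter)), and compound 2 remains the lowest of the three. Nothing at hand explains the gap between these two groups.

Open, as far as these compounds go, is whether a single methyl, a hydroxyl or an amine on the phenyl ring would hold the number of compound 2. Also open, from the compounds shown here alone, is whether a plain alkyl chain could replace the ring on this nitrogen.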